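Anilide swap in the sulfoxide series: cytotoxicity notes

This account rests on a few compounds, and the source may have more. Where it says the series, first, only, none or still open, it means among the compounds named here.

Measured so far:
compound 1, `COc1cc2nc(SCC(=O)Nc3cc([N+](=O)[O-])ccc3F)nc(Nc3c(Cl)cc(/C=C/C#N)cc3Cl)c2cc1OC` — > 199000 nM
compound 2, `COc1cc2nc([S+]([O-])CC(=O)Nc3cccc(Cl)c3)nc(Nc3c(Cl)cc(/C=C/C#N)cc3Cl)c2cc1OC` — 68900 nM

In an ADME assay on MT4 cells (Homo sapiens) for cytotoxicity, read by MTT assay, with a stated time of 5 days (a lower number here means that less compound is tolerated, a higher number that more compound is tolerated), compound 1 returns > 199000 nM, which is a limit of the assay and not a number. Going by the values given here, compound 2 gives 68900 nM in this assay, and this is the only number in the set. Compound 1 instead sits at a limit, (the limit of > 199000 nM in this assay, at which 1 of the 2 values shown sits). Among the compounds with values here, no step between two measured compounds is available, so compound 2 can only be placed as the single numeric point, with compound 1 sitting at the limit.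

Compound 3, `COc1cc2nc([S+]([O-])CC(=O)Nc3ccc(S(N)(=O)=O)cc3)nc(Nc3c(Cl)cc(/C=C/C#N)cc3Cl)c2cc1OC`, keeps the shared core and the sulfoxide-bearing chain of compound 2 and changes the aryl group on the amide-type nitrogen: 4-sulfamoylphenyl in place of 3-chlorophenyl on an amide-type nitrogen. The group that enters brings 1 hydrogen-bond donor and 2 hydrogen-bond acceptors where the 3-chlorophenyl brought none.

Within the data shown here, with no measured step to lean on, the step from compound 2 to compound 3 is expected to be modest in this assay and, if anything, upward, a 2.0-fold higher number from compound 2 to compound 3 (0.31 log units; beyond the scatter). Compound 3 is therefore estimated at 140000 nM in this assay, within 50000 nM to 300000 nM, with a real chance that only a limit is reported.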

Compound 3, half-maximal cytotoxic concentration: > 189000 nM
Compound 3 ended at the assay's limit; the forecaster's own chance of this, stated with the estimate: 45%; at least 1.3-fold (0.13 log units) between middle value and limit.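

In this assay, 4-sulfamoylphenyl in place of 3-chlorophenyl on an amide-type nitrogen gives an at least 2.7-fold higher number from compound 2 to compound 3 (0.43 log units; beyond the scatter). Going by these compounds alone, this is the first step that can be read, and it shows that, with the shared core and the sulfoxide-bearing chain held constant, the aryl group on this nitrogen alone can move the read-out beyond the scatter, with the printed size serving only as a lower bound. Compound 3 stands at a limit of the assay and not at a number: the limit of > 189000 nM in this assay, at which 1 of the 3 values shown sits.

Within the data shown here, compound 1 differs from compound 2 and from compound 3 in more than one place, so no step to it can be read, and the effect of the sulfur oxidation state on its own stays unresolved. Going by these compounds, it also stays open whether the higher number in this assay belongs to the sulfamoyl group specifically or would also follow from another group on the phenyl ring, such as a carboxylic acid or an amine.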